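A few compounds are considered here, and "the series" means these few. Any claim that something is new, unique, unknown or untested is made for them only; others in the source may bear on it.

Two compounds carry numbers in an assay on membranes from Cortex for displacement of a labelled ligand from Sigma non-opioid intracellular receptor 1 (Cavia porcellus), read by scintillation counting, with a stated time of 120 min; on this read-out lower numbers stand for stronger inhibition and higher numbers for weaker inhibition. Compound 2 `O=C(c1ccc(F)cc1)N1CCC(NCCSC(c2ccc(F)cc2)c2ccc(F)cc2)CC1` gives 32.1 nM in this assay, the lower of the two. Compound 1 `[O-][S+](CCNC1CCN(CC(O)Cc2ccccc2)CC1)C(c1ccc(F)cc1)c1ccc(F)cc1` gives 351 nM in this assay, and the gap from compound 2 to compound 1 lies beyond the scatter. Compound 3 `Fc1ccc(C(SCCNC2CCN(CC3CC3)CC2)c2ccc(F)cc2)cc1` awaits measurement in this assay. It differs from compound 2 in one place: cyclopropylmethyl in place of (4-fluorophenyl)carbonyl on an amine nitrogen in a ring. Among the compounds with values here, no pair of measured compounds covers this change, and compound 1 differs from compound 2 in more than one place, so the two measured numbers give no direct guide to its size. Compound 3 is expected to land close to compound 2, the step of a 1.6-fold lower number from compound 2 to compound 3 (0.21 log units; within the scatter) being expected to stay within the scatter, leaning if anything to a lower number. For compound 3 the estimate in this assay is 20 nM, with a range from 5 nM to 80 nM.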

Compound 3, inhibition constant: 269 nM
Compound 3: the middle estimate sits 13-fold (1.13 log units) below what was measured; measured number outside the range, above it.
By their numbers in this assay, from the lowest: compound 2; then compounds 3 and 1 (each within the scatter of the next).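

Within the data shown here, on the amine nitrogen in the six-membered ring, cyclopropylmethyl in place of (4-fluorophenyl)carbonyl gives an 8.4-fold higher number from compound 2 to compound 3 (0.92 log units; beyond the scatter) in this assay and is the first single-place change that can be read. This shows that the group at this position alone can move the number beyond the scatter while the rest of compound 2 stays fixed, but the exchange removes a six-membered aromatic ring and a hydrogen-bond acceptor together, and this one step does not separate them. No measurement shown bears on the reason for the step.

Still open, going by these compounds, is how a 4-fluorobenzyl group, which keeps the aromatic ring without the carbonyl, would read at this nitrogen. An acetyl group, which keeps the carbonyl without the aromatic ring, would test the other half of the change.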